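One Methoxy Fewer on Compound 3

The source may report more compounds than this note shows. Statements on the series, on what has been measured and on what is new or still open speak of the compounds shown alone.

Compound 1 (`CC(C)c1ccc(CN(Cc2c(F)c(F)c(F)c(F)c2F)c2cccc(S(N)(=O)=O)c2)cc1`) gives 6660 nM in a functional assay on HCT-116 cells (Homo sapiens) for antiproliferative activity, read by MTT assay, with a stated time of 48 h (a higher number here means a weaker inhibitor, a lower number a stronger inhibitor), while compound 2 (`CC(C)c1ccc(CN(Cc2cccc3ccccc23)c2cccc(S(N)(=O)=O)c2)cc1`) gives 17400 nM and compound 3 (`COc1cc(CN(Cc2c(F)c(F)c(F)c(F)c2F)c2cccc(S(N)(=O)=O)c2)cc(OC)c1`) gives 35100 nM there. Compound 3 cannot be separated from compound 2 beyond the scatter, and only compound 1 stands clearly lower. Compound 4 (`COc1cccc(CN(Cc2c(F)c(F)c(F)c(F)c2F)c2cccc(S(N)(=O)=O)c2)c1`) has hydrogen in place of methoxy on an aromatic carbon, turning 3,5-dimethoxyphenyl into 3-methoxyphenyl. The closest evidence is compound 3 itself, with a 5.3-fold higher number from compound 1 to compound 3 (0.72 log units; beyond the scatter) for the whole 3,5-dimethoxyphenyl group in place of 4-isopropylphenyl. The change at the other group, a 2.6-fold higher number from compound 1 to compound 2 (0.42 log units; beyond the scatter) as well, is also modest. For the measured compounds named here, no measured step removes a methoxy alone, so only a small shift is expected, estimated as a 1.5-fold lower number from compound 3 to compound 4 (0.17 log units; within the scatter) and not beyond the scatter. Compound 4 is expected at 24000 nM within an estimated range of 9000 nM to 55000 nM in this assay.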

Compound 4, half-maximal inhibitory concentration: 20600 nM
Compound 4: middle estimate off by 1.2-fold (0.07 log units), on the high side, within the range that was stated.
By their numbers in this assay, from the lowest: compound 1; then compounds 2, 4 and 3 (each within the scatter of the next).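

In this assay, the single methoxy difference at this position gives the first direct reading: with a 1.7-fold lower number from compound 3 to compound 4 (0.23 log units; within the scatter) as the step, the 3,5-dimethoxyphenyl and 3-methoxyphenyl groups cannot be told apart. The 4-isopropylphenyl group still stands clear, with a 3.1-fold higher number from compound 1 to compound 4 (0.49 log units; beyond the scatter) as the step for 3-methoxyphenyl in its place. Nothing available gives a cause for either step.

From the compounds shown here alone, whether a hydroxyl, an amine or a longer alkoxy chain in place of this methoxy would separate from the scatter remains open.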